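Working notes on the chain terminus, compound 2 to compound 4

A few compounds are considered here, and "the series" means these few. Any claim that something is new, unique, unknown or untested is made for them only; others in the source may bear on it.

Compound 2 `COC(=O)/C=C/c1cccc(N(Cc2ccc(/C=C/c3ccccn3)cc2)C(=O)C2CCCCC2)c1` gives 309 nM in an assay on isolated protein with Bile acid receptor (Homo sapiens) as the target (on this read-out higher numbers stand for an effect only at larger amounts of compound and lower numbers for an effect already at smaller amounts), and stands at the lowest of the three numbers recorded there. Compound 3 `COC(=O)/C=C/c1cccc(N(Cc2ccc(/C=C/c3ccccn3)cc2)C(=O)C(C)C)c1` gives 310 nM in this assay, and the step from compound 2 is a 1.0-fold higher number from compound 2 to compound 3 (0.00 log units; within the scatter). Compound 1 `COC(=O)/C=C/c1cccc(N(Cc2ccc(/C=C/c3cccc(C(F)(F)F)c3)cc2)C(=O)NC(C)C)c1` gives 932 nM in this assay; it differs from compound 2 in more than one place, so its value is noted only as the furthest of the three from compound 2.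

Compound 4 `COC(=O)/C=C/c1cccc(N(Cc2ccc(/C=C/C(=O)N(C)C)cc2)C(=O)C2CCCCC2)c1` has not yet been measured. It differs from compound 2 as follows: dimethylcarbamoyl in place of pyridin-2-yl on a double-bonded chain carbon bound to a double-bonded chain carbon. For the measured compounds named here, no measured step concerns this position: the only step recorded, a 1.0-fold higher number from compound 2 to compound 3 (0.00 log units; within the scatter), concerns the group on the carbonyl carbon and says nothing about the end of the chain. The change exchanges an aromatic ring for an open chain group, a larger alteration than any already recorded, so a move toward a higher number is expected rather than none.

Compound 4 is therefore estimated at 1000 nM, within 300 nM to 3500 nM. Going by the values given here, the expected step of a 3.2-fold higher number from compound 2 to compound 4 (0.51 log units; beyond the scatter) rests on no measured analogue and carries wide uncertainty.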

Compound 4, half-maximal effective concentration: > 1000 nM
Compound 4 ended at the assay's limit; the forecaster's own chance of this, stated with the estimate: 10%; the middle value lies on the limit itself.
By their numbers in this assay, from the lowest: compounds 2 and 3 (each within the scatter of the next); then compound 1. At a limit, above all of these: compound 4.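

Compound 4 reaches a limit of this assay, with > 1000 nM being a limit and not a number. Dimethylcarbamoyl in place of pyridin-2-yl on a double-bonded chain carbon bound to a double-bonded chain carbon gives an at least 3.2-fold higher number from compound 2 to compound 4 (0.51 log units; beyond the scatter), so this end of the chain responds to change, whereas the exchange on the carbonyl carbon gave a 1.0-fold higher number from compound 2 to compound 3 (0.00 log units; within the scatter). The true size of the step at the chain end remains unfixed: the limit of > 1000 nM in this assay, at which 1 of the 4 values shown sits.

From the compounds shown here alone, whether the ring at the chain end is needed, or only dimethylcarbamoyl is poorly accepted there, stays open. A plain phenyl, a pyridin-4-yl, a piperidine amide or a carboxylic acid at the same place would help separate these readings.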